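Working notes: a hydroxy group added to compound 1

A few compounds are considered here, and "the series" means these few. Any claim that something is new, unique, unknown or untested is made for them only; others in the source may bear on it.

Compound 1 `CSc1cccc(CSc2nc(-c3ccc(F)cc3)c(-c3ccncc3)[nH]2)c1`: 550 nM
Compound 2 `Fc1ccc(-c2[nH]c(SCc3ccccc3)nc2-c2ccncc2)cc1`: 300 nM

Both values come from a functional assay (Homo sapiens) for inhibition; a lower number here means a stronger inhibitor, a higher number a weaker inhibitor. Compound 1 stands within the scatter of compound 2, so these two measurements do not separate the compounds. They give a narrow base for any forecast.

The next compound to be measured is compound 3 `CSc1cc(CSc2nc(-c3ccc(F)cc3)c(-c3ccncc3)[nH]2)ccc1O`. It differs from compound 1 by a single change: hydroxy in place of hydrogen on an aromatic carbon. This is hydroxy in place of hydrogen on an aromatic carbon, ortho to a methylsulfanyl group and para to a large group.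

Among the measured compounds shown here, no measured pair shows a step of this kind, so the data offer no precedent for its size or direction. The expectation therefore rests on compound 1 at 550 nM and on compound 2 at 300 nM, and no step beyond the scatter is expected. The estimated step of a 1.4-fold lower number from compound 1 to compound 3 (0.14 log units; within the scatter) stays within that scatter, and its direction is uncertain. For compound 3 the expected value in this assay is 400 nM, with an estimated range of 120 nM to 1300 nM.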

Compound 3, half-maximal inhibitory concentration: 280 nM
Estimate against measurement, compound 3: 1.4-fold (0.15 log units) above, within the range that was stated.
By their numbers in this assay, from the lowest: compounds 3, 2 and 1 (each within the scatter of the next).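

Adding hydroxy at this aromatic carbon, ortho to a methylsulfanyl group and para to a large group, gives the only step measured so far on this ring in this assay (a 2.0-fold lower number from compound 1 to compound 3 (0.29 log units; within the scatter)). The position therefore accepts a hydroxy group, which brings one hydrogen-bond donor and one hydrogen-bond acceptor, without a step beyond the scatter, and compound 3 at 280 nM remains an inhibitor in the same range as compound 1 at 550 nM. The data shown offer nothing that bears on the reason for this step.

On these data alone, a single step within the scatter gives no direction for other replacements, so it remains open whether methoxy, an amine or a carboxylic acid at this same carbon would give a step beyond the scatter in this assay. As far as these compounds go, it is also open whether hydroxy would give a similar step at another carbon of this ring, or on a ring without the methylsulfanyl group.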